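Thiophene in place of difluorophenyl: a solubility expectation

The source may hold more compounds than are shown below. What is called first, only, known or untested is meant among the compounds shown, and "the series" means these compounds.

Measured so far in a physicochemical assay for solubility, read by HPLC, using the shake flask method, measured as kinetic solubility, with a stated time of 2 h, at pH 7.4; on this read-out higher numbers stand for higher solubility and lower numbers for lower solubility:
compound 1 `Cc1cc(NCc2ccccn2)n2ncc(-c3ccccc3F)c2n1`: 5000 nM
compound 2 `Cc1cc(NCc2ccccn2)n2ncc(-c3ccc(F)cc3F)c2n1`: < 5000 nM

In this assay compound 1 gives 5000 nM. In this assay compound 2 gives < 5000 nM, which is a limit of the assay and not a number (the limit of < 5000 nM in this assay, at which 1 of the 2 values shown sits). The measured step of a number no higher from compound 1 to compound 2 (the limit leaves the size open) therefore has no readable size, so compound 2 stands only at that limit.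

Compound 3 `Cc1cc(NCc2ccccn2)n2ncc(-c3ccsc3)c2n1` differs from compound 2 by thiophen-3-yl in place of 2,4-difluorophenyl on an aromatic carbon. Among the compounds with values here, no measured step concerns this change; the single measured step, a number no higher from compound 1 to compound 2 (the limit leaves the size open), concerns fluoro in place of hydrogen on an aromatic carbon and leaves its size open. Nothing measured therefore fixes a direction for compound 3 in this assay. Compound 3 is estimated at 5000 nM, expected between 2000 nM and 12000 nM. The step of a number no lower from compound 2 to compound 3 (the limit leaves the size open) is thus expected to stay within the scatter.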

Compound 3, solubility: 9000 nM
Beside the measured number, compound 3's estimate is 1.8-fold (0.26 log units) below it, and the stated range covers the measured number.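

At this aromatic carbon of the five-membered aromatic ring with 2 nitrogen, a ring other than a fluorinated phenyl now gives a step with a lower bound in this assay, where the fluoro step had none: the exchange for 2,4-difluorophenyl shows an at least 1.8-fold higher number from compound 2 to compound 3 (0.25 log units; that floor lies within the scatter). That step rests on the value of compound 2, which is a limit of the assay and not a number: the limit of < 5000 nM in this assay, at which 1 of the 3 values shown sits.

Within the data shown here, the one comparison between two full numbers is a 1.8-fold higher number from compound 1 to compound 3 (0.26 log units; within the scatter), so this exchange of rings stays inside the usual scatter where thiophen-3-yl takes the place of 2-fluorophenyl.

On these data alone, the true size of the step from the 2,4-difluorophenyl compound remains open. The compounds shown also leave open how a pyridine ring, thiophen-2-yl or an amine on this carbon would read out.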